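The compounds below may be only part of what the source reports. "The series", "measured", "known", "first", "only" and "open" are said of these compounds alone.

Compound 1 `CS(=O)(=O)c1ccc(C(=O)N2CCC(C(=O)N3CCc4ccccc43)CC2)cc1[N+](=O)[O-]` was examined in an assay on isolated protein for inhibition of vitamin D3 receptor (Homo sapiens), read by fluorescence polarization; on this read-out lower numbers stand for stronger inhibition and higher numbers for weaker inhibition. In this assay compound 1 gives a value that is a limit of the assay rather than a number, > 60000 nM. Two related compounds share that outcome. Compound 2 `CS(=O)(=O)c1ccc(C(=O)NCCC(=O)N2CCCc3ccccc32)cc1[N+](=O)[O-]` likewise reaches only a limit in this assay, > 60000 nM. Compound 3 `CC(C)N(C(=O)CNC(=O)c1ccc(S(C)(=O)=O)c([N+](=O)[O-])c1)C(C)C` also gives a limit in this assay, > 60000 nM. The whole measured set thus sits at the limit of > 60000 nM in this assay, at which 3 of the 3 values shown sit, so compound 1 stands nowhere in particular among the numbers shown: no compound has a measured number at all, and no step between two measured compounds can be traced.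

Compound 4 `CC1Cc2ccccc2N1C(=O)C1CCN(C(=O)c2ccc(S(C)(=O)=O)c([N+](=O)[O-])c2)CC1` has not yet been measured. Compared with compound 1 it carries one small change, (methyl in place of hydrogen on a saturated ring carbon), in words methyl in place of hydrogen on a saturated ring carbon. For the measured compounds named here, with every measured compound resting at the limit, there is no measured step to set a scale for what such a change does, and the change itself is a small one. The expected step is therefore a step that the limit leaves unreadable from compound 1 to compound 4, none beyond the scatter. Compound 4 is estimated to give 100000 nM in this assay, within a range from 40000 nM to 300000 nM, most probably again reported as a limit rather than a number.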

Compound 4, half-maximal inhibitory concentration: > 60000 nM
Compound 4 ended at the assay's limit; the forecaster's own chance of this, stated with the estimate: 90%; the middle value does not contradict the limit.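

Compound 1 and compound 4 both rest at a limit of this assay, so the step that carries methyl in place of hydrogen on a saturated ring carbon cannot be read: the limit of > 60000 nM in this assay, at which 4 of the 4 values shown sit.

The compounds shown leave open how strongly, if at all, any of them inhibits in this assay, and whether that methyl changes inhibition.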